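The source may report more compounds than this note shows. Statements on the series, on what has been measured and on what is new or still open speak of the compounds shown alone.

Compound 1, `Cc1ccc(S(=O)(=O)c2cnc3ccc(Cl)cc3c2N2CCC(C)CC2)cc1`: in an assay on isolated protein for displacement of a labelled ligand from metabotropic glutamate receptor 5 (Homo sapiens), with a stated time of 60 min, tested at 1 uM (a higher number here means more inhibition at the concentration tested (going by the name of the read-out), a lower number less inhibition), compound 1 gives 95%.
Compound 2, `CC1CCN(c2c(S(=O)(=O)c3ccc(Cl)cc3)cnc3cc(Cl)ccc23)CC1`: in this assay compound 2 gives 91%.
Compound 3, `COc1ccc2ncc(S(=O)(=O)c3cccc(C#N)c3)c(N3CCC(C)CC3)c2c1`: in this assay compound 3 gives 90%.

All three compounds share the same core and the same piperidine, and differ only in the aromatic ring carried on the sulfonyl sulfur. Of the three numbers, compound 3 has the lowest. Compound 2 lies closest to it and compound 1 furthest from it, yet both gaps fall within the usual scatter of repeated measurements, so none of the three can be ranked against the others; all inhibit strongly at the concentration tested.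

Compound 4, `COc1ccc2ncc(S(=O)(=O)c3ccc(Cl)c(Cl)c3)c(N3CCC(C)CC3)c2c1`, has not yet been measured. It arises from compound 3 by one change: 3,4-dichlorophenyl in place of 3-cyanophenyl on a sulfonyl sulfur. The rest of the molecule stays as it is. For the measured compounds named here, no measured pair in this set shows exactly this exchange, so there is no measured step to lean on. Compound 2, which also carries chlorine on the ring attached to the sulfonyl sulfur, gives 91%, and compound 3 gives 90%, both near the top of the read-out. The step of a number 1 percentage points higher from compound 3 to compound 4 (within the scatter) is therefore expected to be small, no larger than the scatter, in either direction. Compound 4 is expected to give 91%, within a range from 80% to 98%.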

Compound 4, a percentage reported as inhibition, at one concentration (the size of the read-out at that concentration, not a potency): 87%
Beside the measured number, compound 4's estimate is 4 percentage points above it; measured number inside the range.
By their numbers in this assay, from the lowest: compounds 4, 3, 2 and 1 (each within the scatter of the next).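

In this assay, for the compounds shown here, putting 3,4-dichlorophenyl in place of 3-cyanophenyl on a sulfonyl sulfur gives a number 3 percentage points lower from compound 3 to compound 4 (within the scatter) and is the first step here that changes one place alone. With the rest of the molecule held fixed, the read-out does not tell the two rings apart, even though the nitrile with its triple bond leaves and chlorine enters. Going by these compounds alone, this place on the sulfonyl sulfur therefore accepts both rings with strong inhibition at the concentration tested, something the earlier compounds could not show on their own since none of them formed a pair differing in one place. No measured evidence is available to explain this result.

The compounds shown leave open whether a phenyl ring carrying an amine or a carboxylic acid, or a plain ethyl chain in place of the ring, would keep inhibition at this level on the sulfonyl sulfur. As far as these compounds go, a percentage at one concentration is also not a potency, and so it remains open whether the two compounds would separate at lower concentrations.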